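Bromo Substitution on the Lactam Ring of Compound 1

A few compounds are considered here, and "the series" means these few. Any claim that something is new, unique, unknown or untested is made for them only; others in the source may bear on it.

Three trimethoxyphenyl acrylamides have been measured in a functional assay on A549 cells (Homo sapiens) for cytotoxicity, read by MTT assay, with a stated time of 72 h; a higher number here means a weaker inhibitor, a lower number a stronger inhibitor. Compound 1 `COc1cc(/C=C(\C)C(=O)N2CCC=CC2=O)cc(OC)c1OC` gives 24000 nM, the highest number of the three. In this assay compound 2 `COc1cc(/C=C/C(=O)N2CCC=C(Br)C2=O)cc(OC)c1OC` gives 4790 nM, and compound 3 `CCC/C(=C\c1cc(OC)c(OC)c(OC)c1)C(=O)N1CCC=C(Cl)C1=O` gives 3810 nM; both of these steps from compound 1 are beyond the usual scatter, so compound 1 is the weakest inhibitor among the measured compounds.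

Compound 4 `COc1cc(/C=C(\C)C(=O)N2CCC=C(Br)C2=O)cc(OC)c1OC` has not yet been measured. It differs from compound 1 in one place: bromo in place of hydrogen on a double-bonded ring carbon. Among the measured compounds shown here, no direct step between measured compounds isolates this change, so the expectation for compound 4 rests on the spread of the measured values and on the nature of the change.

Because compound 2 gives 4790 nM and compound 3 gives 3810 nM, both halogen-bearing compounds sit well below compound 1, and a halogen on the same ring of compound 1 is expected to lower its number in this assay by a similar margin. Compound 4 is therefore estimated at 5000 nM, with a range from 1800 nM to 14000 nM. The step from compound 1 to compound 4 is expected to be a 4.8-fold lower number from compound 1 to compound 4 (0.68 log units; beyond the scatter), a gain in potency beyond the scatter.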

Compound 4, half-maximal inhibitory concentration: 2670 nM
For compound 4 the middle estimate is 1.9-fold (0.27 log units) above the measured one; the range from low to high includes it.
By their numbers in this assay, from the lowest: compounds 4, 3 and 2 (each within the scatter of the next); then compound 1.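

In this assay, bromo in place of hydrogen on a double-bonded ring carbon, two ring bonds from the ring nitrogen, gives a 9.0-fold lower number from compound 1 to compound 4 (0.95 log units; beyond the scatter), with the rest of the structure unchanged. Among the compounds shown here, this is the first step that isolates a halogen at this position: compound 2 and compound 3 each differ from compound 1 in more than one place, so their lower numbers could not be assigned to the halogen alone, whereas here a single added bromine atom is enough to move the number beyond the scatter. None of the data shown explains how the bromo produces this effect on cytotoxicity.

As far as these compounds go, whether a different group on this same ring carbon, such as fluoro, a nitrile or an amine, would give a step of similar size remains open. From the compounds shown here alone, it is also open whether the bromo step would keep its size on a compound with a longer chain in place of the methyl group of compound 1.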